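Bromo to dichloro on the benzyl arm of a shared core

The compounds below may be only part of what the source reports. "The series", "measured", "known", "first", "only" and "open" are said of these compounds alone.

Compound 1 `COc1ccc(CSc2nnc(-c3cc([N+](=O)[O-])cc([N+](=O)[O-])c3)n2C)cc1` in an ADME assay on A-431 cells (Homo sapiens) for cytotoxicity, with a stated time of 48 h (a lower number here means a stronger inhibitor, a higher number a weaker inhibitor), gives > 30000 nM, which is a limit of the assay and not a number.
Compound 2 `Cn1c(SCc2ccc(Br)cc2)nnc1-c1cc([N+](=O)[O-])cc([N+](=O)[O-])c1` in this assay gives > 30000 nM, again a limit.

The step that the two limits leave unreadable from compound 1 to compound 2 cannot be sized; the limit of > 30000 nM in this assay, at which 2 of the 2 values shown sit, is all that is known. Compound 3 `Cn1c(SCc2ccc(Cl)c(Cl)c2)nnc1-c1cc([N+](=O)[O-])cc([N+](=O)[O-])c1` differs from compound 2 by 3,4-dichlorophenyl in place of 4-bromophenyl on a saturated chain carbon bound to a sulfur. With no readable step to lean on, compound 3 is expected to stay near the same limit, a step that the limit leaves unreadable from compound 2 to compound 3 at most, with weak inhibition of the cells most likely. For compound 3 the estimate is 40000 nM, within 15000 nM to 100000 nM.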

Compound 3, half-maximal inhibitory concentration: > 30000 nM
Compound 3: a limit, no number; the forecaster's own chance of this, stated with the estimate: 85%; the middle value is on the limit's open side.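

Compound 1, compound 2 and compound 3 all end at a limit of the assay rather than a number, so no step among them can be read: the limit of > 30000 nM in this assay, at which 3 of the 3 values shown sit.

How strongly any of these compounds inhibits the cells remains open, as does whether the benzyl arm changes that at all.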